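Methoxy removal on the aryl ketone across two cores

The source may hold more compounds than are shown below. What is called first, only, known or untested is meant among the compounds shown, and "the series" means these compounds.

Three compounds of the series have been run in a functional assay on SN12C cells (Homo sapiens) for inhibition, read by sulforhodamine B assay, with a stated time of 48 h; on this read-out higher numbers stand for weaker inhibition of growth and lower numbers for stronger inhibition of growth. Compound 1 `COc1ccc(-c2cc(/C=C/C(=O)c3ccc(N)cc3)[nH]n2)cc1` gives 6630 nM. Compound 2 `COc1ccc(-c2cc(/C=C/C(=O)c3ccc(N)cc3)[nH]n2)cc1OC` gives 13700 nM. Compound 3 `COc1cc(C(=O)/C=C/c2cc(-c3cc(OC)c(OC)c(OC)c3)n[nH]2)cc(OC)c1OC` gives 2970 nM, the lowest of the three; its nearest neighbour is compound 1 and its furthest is compound 2, both steps lying beyond the scatter. The difference between the core of compound 2 and the core of compound 3 is not broken down here.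

For the measured compounds named here, the one counted step within the measured set is hydrogen in place of methoxy on an aromatic carbon, which produced a 2.1-fold lower number from compound 2 to compound 1 (0.32 log units; beyond the scatter), a modest step beyond the scatter.

Compound 4 `COc1ccc(-c2cc(/C=C/C(=O)c3cc(OC)c(OC)c(OC)c3)[nH]n2)cc1OC` has not yet been run in this assay. It differs from compound 3 by hydrogen in place of methoxy on an aromatic carbon. Going by the values given here, this is the same kind of change as the one from compound 2 to compound 1, but not the same: in compound 3 the place is ortho to a methoxy group, meta to a large group and meta to a methoxy group, whereas in compound 2 the place is ortho to a methoxy group and meta to a large group only.

Going by that single precedent, compound 4 is expected to show a 1.9-fold lower number from compound 3 to compound 4 (0.27 log units; within the scatter) in this assay, a step of about the size seen from compound 2 to compound 1, because the earlier change gave a 2.1-fold lower number from compound 2 to compound 1 (0.32 log units; beyond the scatter). The expectation rests on one pair alone, so the range is kept wide. Compound 4 is estimated at 1600 nM, with a likely span from 700 nM to 4000 nM.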

Compound 4, concentration for total growth inhibition: 3830 nM
Compound 4: the middle estimate sits 2.4-fold (0.38 log units) below what was measured; measured number inside the range.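

In this assay, hydrogen in place of methoxy gave a 1.3-fold higher number from compound 3 to compound 4 (0.11 log units; within the scatter), so on the core of compound 3 the change leaves the read-out inside the usual scatter, and this step does not match the one seen earlier: the same change on two cores in this assay, a 2.1-fold lower number (0.32 log units; beyond the scatter) from compound 2 to compound 1 and a 1.3-fold higher number (0.11 log units; within the scatter) from compound 3 to compound 4, 2.7-fold (0.43 log units) apart, beyond the scatter of two such steps

This shows that the size of the step on the core of compound 2 cannot be carried as a fixed increment to the core of compound 3, and any estimate for this change on a further core in the series should start from that mismatch. It does not show why the two steps part: the place on compound 3 is also meta to a methoxy group, the two cores differ elsewhere as well, and two pairs cannot separate these features or give a rule for the series.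

The compounds shown leave open whether the step on a third core would resemble either of these two. They also leave open what a hydroxyl group, a fluorine atom or a carboxylic acid would do at this place, on either core, in place of the methoxy group.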